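Chlorine substitution on the indolinone-bearing series: cytotoxicity notes

The compounds below may be only part of what the source reports. "The series", "measured", "known", "first", "only" and "open" are said of these compounds alone.

Measured compounds:
compound 1 `COc1ccc(C2=NN(C3=NC(=O)/C(=C4\C(=O)Nc5ccccc54)S3)C(c3ccc(OC)cc3)C2)cc1` — 100000 nM
compound 2 `COc1ccc(C2=NN(C3=NC(=O)/C(=C4\C(=O)Nc5ccccc54)S3)C(c3ccc(Cl)cc3)C2)cc1` — 100000 nM

In a functional assay on cells (Melanoma cell, Homo sapiens) for cytotoxicity, read by sulforhodamine B assay, with a stated time of 48 h (a higher number here means a weaker inhibitor of growth, a lower number a stronger inhibitor of growth), compound 1 gives 100000 nM. In this assay compound 2 gives 100000 nM. The step of no change at the digits printed from compound 1 to compound 2 (within the scatter), chloro in place of methoxy on an aromatic carbon, is within the scatter, so compound 2 stands level with compound 1 on the numbers shown, both at the upper end of the range measured.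

Compound 3 `COc1ccc(C2=NN(C3=NC(=O)/C(=C4\C(=O)Nc5ccc(Cl)cc54)S3)C(c3ccc(Cl)cc3)C2)cc1` differs from compound 2 by chloro in place of hydrogen on an aromatic carbon, a single chlorine entering on the fused two-ring portion. Within the data shown here, the only step that bears on this change is the one from compound 1 to compound 2, which brought no movement beyond the scatter; no step on the fused ring itself has been measured. With nothing showing that a chloro entering anywhere shifts growth inhibition, no step beyond the scatter is expected in this assay, no change at the digits printed from compound 2 to compound 3 (within the scatter). Compound 3 is therefore estimated at 100000 nM, with a range from 30000 nM to 100000 nM.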

Compound 3, concentration for total growth inhibition: 440 nM
Compound 3: middle estimate off by 230-fold (2.36 log units), on the high side; measured number below the stated range.
By their numbers in this assay, from the lowest: compound 3; then compounds 1 and 2 (each within the scatter of the next).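

In this assay, chloro in place of hydrogen on an aromatic carbon of the fused system of two rings gives a 230-fold lower number from compound 2 to compound 3 (2.36 log units; beyond the scatter), whereas chloro in place of methoxy on an aromatic carbon gave no change at the digits printed from compound 1 to compound 2 (within the scatter) in the same background. Entry of a chlorine therefore does not have one outcome across these compounds: the number depends on where the chlorine enters and what it replaces, and this position on the fused system is the first shown where a single change moves growth inhibition beyond the scatter. No measurement at hand speaks to what lies behind this step.

On these data alone, it remains open whether fluoro, methyl, methoxy or an amine in that same place would bring a comparable step. Also open, as far as these compounds go, is whether the step from the fused-system chloro depends on the chloro already present in compound 2.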